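Amide nitrogen variation in the paw edema series

This account rests on a few compounds, and the source may have more. Where it says the series, first, only, none or still open, it means among the compounds named here.

Within the data shown here, the series so far holds two measured compounds. Compound 1 `COc1cc2c(cc1OC)C(CC(=O)O)CC2` carries a free carboxylic acid on the shared core; in a functional assay on the whole organism (strain Wistar) for inhibition, with Rattus norvegicus as the target, read by paw edema, with stated times of 60 min and 2 h, at a dose of 100 mg/kg by the oral route (on this read-out lower numbers stand for less inhibition and higher numbers for more inhibition at the one dose given (going by the name of the read-out)), compound 1 gives 24%. Compound 2 `COc1cc2c(cc1OC)C(CC(=O)NC(C)C)CC2` is the isopropylamide of the same acid; in this assay compound 2 gives 37%. Among the measured compounds shown here, compound 2 thus stands at the top of the two numbers measured, the step of a number 13 percentage points higher from compound 1 to compound 2 (beyond the scatter) being the only measured step.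

Compound 3 `CCCCNC(=O)CC1CCc2cc(OC)c(OC)cc21` is the next member. Compared with compound 2 it differs in one place: butyl in place of isopropyl on an amide-type nitrogen. For the measured compounds named here, no measured step touches this kind of change: the one step known, a number 13 percentage points higher from compound 1 to compound 2 (beyond the scatter), concerns isopropylamino in place of hydroxy on the carbonyl carbon, not a change within the substituent on the amide nitrogen, so it gives only a weak anchor, namely that an amide of this type sits above the free acid. With nothing to indicate a direction, the step expected in this assay is no change at the digits printed from compound 2 to compound 3 (within the scatter), that is none beyond the scatter. Compound 3 is therefore estimated at 37%, with a range from 22% to 52%.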

Compound 3, a percentage reported as inhibition, in the whole organism at one dose (the size of the read-out at that dose, not a potency): 24%
The estimate for compound 3 lay 13 percentage points above the measured number; measured number inside the range.
By their numbers in this assay, from the lowest: compounds 1 and 3 (each within the scatter of the next); then compound 2.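

Notes on the amide nitrogen: in this assay, the substituent on this nitrogen proves to matter, since butyl in place of isopropyl gives a number 13 percentage points lower from compound 2 to compound 3 (beyond the scatter), the first measured step within this substituent. The amide alone therefore does not carry the higher number: butylamino in place of hydroxy on a carbonyl carbon gives no change at the digits printed from compound 1 to compound 3 (within the scatter), so among the two amides shown, only the isopropylamino one stands above the free acid. Nothing at hand bears on why the isopropyl and butyl amides part in this way.

The compounds shown leave open whether the difference follows chain length, branching or something specific to isopropyl, as one branched and one straight chain of different sizes cannot separate these readings. A propyl chain, a tert-butyl group or a cyclopropyl ring on the same nitrogen would bear on that question, and a primary amide would show how the series reads with no carbon substituent there at all.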